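Swapping a Benzyl Substituent: From Compound 3 to Compound 4

A few compounds are considered here, and "the series" means these few. Any claim that something is new, unique, unknown or untested is made for them only; others in the source may bear on it.

Measured compounds:
Compound 1 `CCN(CC)c1ccc2cc(C(=O)c3ccc(N4CCN(C(=O)CN5CCNCC5)CC4)cc3)oc2c1`: 1350 nM
Compound 2 `CCN(CC)c1ccc2cc(C(=O)c3ccc(N4CCN(C(=O)CN5CCN(C(=O)CCl)CC5)CC4)cc3)oc2c1`: 5520 nM
Compound 3 `CCN(CC)c1ccc2cc(C(=O)c3ccc(N4CCN(C(=O)CN5CCN(Cc6ccc(/C=C/C(=O)OC)cc6)CC5)CC4)cc3)oc2c1`: 3040 nM

In a functional assay on HeLa cells (Homo sapiens) for cytotoxicity, read by MTT assay, with a stated time of 48 h (on this read-out higher numbers stand for weaker inhibition and lower numbers for stronger inhibition), compound 3 gives 3040 nM, the second highest of the three numbers; compound 2 lies within the scatter of it, while compound 1 sits beyond the scatter at a lower number. Compound 4 `CCN(CC)c1ccc2cc(C(=O)c3ccc(N4CCN(C(=O)CN5CCN(Cc6ccc(C(F)(F)F)cc6)CC5)CC4)cc3)oc2c1` differs from compound 3 by one change: trifluoromethyl in place of 2-(methoxycarbonyl)ethenyl on an aromatic carbon. Among the measured compounds shown here, the only step measured so far, a 4.1-fold higher number from compound 1 to compound 2 (0.61 log units; beyond the scatter), concerns a different place in the molecule and therefore says little about swapping one group on the benzyl ring for another. For the measured compounds named here, with no comparable step to lean on, the expectation is a number close to that of compound 3, with no change beyond the scatter, so a 1.0-fold lower number from compound 3 to compound 4 (0.01 log units; within the scatter) is estimated. Compound 4 is therefore expected to give about 3000 nM, ranging from 1400 nM to 6500 nM.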

Compound 4, half-maximal inhibitory concentration: > 40000 nM
Compound 4 ended at the assay's limit (the forecaster's own chance of this, stated with the estimate: 5%); at least 13-fold (1.12 log units) between middle value and limit.
By their numbers in this assay, from the lowest: compound 1; then compounds 3 and 2 (each within the scatter of the next). At a limit, above all of these: compound 4.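

In this assay compound 4 gives a limit of the assay rather than a number: the limit of > 40000 nM in this assay, at which 1 of the 4 values shown sits.
Putting trifluoromethyl on the benzyl ring gives an at least 13-fold higher number from compound 3 to compound 4 (1.11 log units; beyond the scatter) and shows that this position alone can decide the outcome. The 4-(trifluoromethyl)benzyl group on the amine nitrogen in a ring also reads weaker than the other two substituents there, with an at least 7.2-fold higher number from compound 2 to compound 4 (0.86 log units; beyond the scatter) and an at least 29-fold higher number from compound 1 to compound 4 (1.47 log units; beyond the scatter) in each case.

From the compounds shown here alone, it remains open whether the weakening comes from removing 2-(methoxycarbonyl)ethenyl or from adding trifluoromethyl. A benzyl ring carrying a plain hydrogen, an amine or a carboxylic acid at that place would help separate the two.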